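Carboxy for Ester on the Aryl Ether of Compound 2

A few compounds are considered here, and "the series" means these few. Any claim that something is new, unique, unknown or untested is made for them only; others in the source may bear on it.

The measured compounds and their values:
compound 1, `COC(=O)c1ccc(OCCCCOc2ccc(C(=O)CC3CCCC3)c(O)c2C)cc1`, gives 12.2% in an assay on HEK293 cells for positive allosteric modulation of metabotropic glutamate receptor 2 (Rattus norvegicus), read by thallium flux, with a stated time of 2.5 min; on this read-out lower numbers stand for smaller maximal responses and higher numbers for larger maximal responses;
compound 2, `COC(=O)c1ccc(OCCCCOc2ccc(C(=O)CC3CCCC3)c(C)c2C)cc1`, gives 14.1% in this assay;
compound 3, `Cc1c(OCCCCOc2cccc(C(=O)O)c2)ccc(C(=O)CC(C)C)c1O`, gives 84.5% in this assay.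

Compound 2 stands second highest of the three numbers. Its nearest neighbour is compound 1, and the step of a number 1.9 percentage points higher from compound 1 to compound 2 (within the scatter) lies within the scatter. Compound 3 stands far above it; the two values differ beyond the scatter, but the structures differ in more than one place, so no single step can be read from them.

Compound 4, `Cc1c(OCCCCOc2ccc(C(=O)O)c(Cl)c2)ccc(C(=O)CC2CCCC2)c1C`, is not yet measured. It differs from compound 2 by 4-carboxy-3-chlorophenyl in place of 4-(methoxycarbonyl)phenyl on an oxygen on a saturated carbon. Within the data shown here, the only measured step, from compound 1 to compound 2, concerns a methyl in place of a hydroxy on the core and says nothing about the aryl ether end. Among the measured compounds shown here, compound 3, the one compound carrying a carboxy group, shows the high number 84.5%, but its core also differs, so the weight of this hint is uncertain. A rise beyond the scatter is therefore expected for compound 4 in this assay, tentatively, as a number 30.9 percentage points higher from compound 2 to compound 4 (beyond the scatter). Compound 4 is estimated at 45%, between 15% and 80%.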

Compound 4, largest response reached (reported as percent of maximum), in percent of the reference or control that the assay uses: 61.8%
Estimate against measurement, compound 4: 16.8 percentage points below, and the stated range covers the measured number.
By their numbers in this assay, from the lowest: compounds 1 and 2 (each within the scatter of the next); then compound 4; then compound 3.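

With the shared core held constant, the exchange of 4-(methoxycarbonyl)phenyl for 4-carboxy-3-chlorophenyl on an oxygen on a saturated carbon gives a number 47.7 percentage points higher from compound 2 to compound 4 (beyond the scatter) in this assay. Among these compounds, this is the first direct reading at the aryl ether end, and it shows that this end of the molecule can move the maximal response far beyond the scatter, whereas the one earlier step, made on the core, stayed within it. No measurement shown here accounts for the size of this rise.

As far as these compounds go, the change replaces the ester with a carboxylic acid and adds a chlorine in one step, so the share of each remains open: a 4-carboxyphenyl group without the chlorine, or a 4-(methoxycarbonyl)phenyl group carrying it, would be needed to separate them. From the compounds shown here alone, it also remains open whether a hydroxy in place of the methyl on the core, which made no difference beyond the scatter with the ester in place, would behave the same way alongside the carboxylic acid, and whether an amide or a tetrazole could stand in for that acid.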